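Replacing bromo with phenyl on a lone measured compound

This account rests on a few compounds, and the source may have more. Where it says the series, first, only, none or still open, it means among the compounds named here.

Compound 1 `O=C(Nc1ccc(Cl)cc1)c1cc(=O)[nH]c2cc(Br)ccc12`: > 20000 nM (a limit, not a number)
Compound 2 `O=C(Nc1cc(F)ccc1F)c1cc(=O)[nH]c2cc(Br)ccc12`: > 20000 nM (a limit, not a number)
Compound 3 `O=C(Nc1cccc(F)c1)c1cc(=O)[nH]c2cc(Br)ccc12`: 8900 nM

Among the measured compounds shown here, in a functional assay on KYSE-70 cells for antiproliferative activity against KYSE-70 cell line (Homo sapiens), read by MTT assay, with a stated time of 72 h (on this read-out higher numbers stand for weaker inhibition and lower numbers for stronger inhibition), compound 3 gives 8900 nM, the only true number among the three. Compound 1 and compound 2 reach only (the limit of > 20000 nM in this assay, at which 2 of the 3 values shown sit). Compound 3 therefore stands as the most active of the three, with an at least 2.2-fold lower number from compound 1 to compound 3 (0.35 log units; beyond the scatter) and an at least 2.2-fold lower number from compound 2 to compound 3 (0.35 log units; beyond the scatter).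

Compound 4 `O=C(Nc1cccc(F)c1)c1cc(=O)[nH]c2cc(-c3ccccc3)ccc12` keeps the amide part of compound 3 and changes the core: phenyl in place of bromo on an aromatic carbon. Both measured steps alter the group on the amide nitrogen, while the bromo is present in all three measured compounds. For the measured compounds named here, no measured step therefore tests this swap, and neither its size nor its direction can be read from the data. What the steps do show is that a single change can move the number beyond the scatter, as in an at least 2.2-fold lower number from compound 2 to compound 3 (0.35 log units; beyond the scatter). The expectation therefore starts from compound 3 at 8900 nM and needs a wide range on both sides. The expected change is modest, with only a slight lean towards stronger inhibition: a 1.5-fold lower number from compound 3 to compound 4 (0.17 log units; within the scatter). For compound 4 the estimated value is 6000 nM, with an expected range from 1500 nM to 20000 nM.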

Compound 4, half-maximal inhibitory concentration: > 20000 nM
Compound 4 gave a limit, no number (the forecaster's own chance of this, stated with the estimate: 25%); middle value at least 3.3-fold (0.52 log units) away from the limit.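

Among the compounds shown here, until now, every measured step changed the group on the amide nitrogen, while the bromo stayed in place; this is the first step to show that the core position also affects the read-out. With the 3-fluorophenyl amide held fixed in this assay, phenyl in place of bromo on this aromatic carbon gives an at least 2.2-fold higher number from compound 3 to compound 4 (0.35 log units; beyond the scatter), so here the added ring does not improve on bromo and weakens inhibition. Compound 4 gives > 20000 nM, which is a limit and not a number, and the full size of the loss stays hidden because the measured range ends there for most of this small set: the limit of > 20000 nM in this assay, at which 3 of the 4 values shown sit.

As far as these compounds go, only bromo and phenyl appear at this position, so it remains open whether an amine, a methoxy group, or simply a hydrogen there would give a lower or a higher number than bromo. From the compounds shown here alone, it also remains open whether phenyl would have the same effect with a different group on the amide nitrogen, and whether a ring carrying a carboxylic acid would behave like plain phenyl.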